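This account rests on a few compounds, and the source may have more. Where it says the series, first, only, none or still open, it means among the compounds named here.

Measured compounds:
Compound 1 `COc1cc2c(Oc3ccc(NC(=O)N/N=C/c4ccc([N+](=O)[O-])cc4)cc3F)ccnc2cc1OCCCN1CCCC1` gives 970 nM in a functional assay on MDA-MB-231 cells (Homo sapiens) for cytotoxicity, read by MTT assay, with a stated time of 72 h; a lower number here means a stronger inhibitor, a higher number a weaker inhibitor.
Compound 2 `COc1cc2c(Oc3ccc(NC(=O)N/N=C/c4ccc(F)cc4Cl)cc3F)ccnc2cc1OCCCN1CCCCC1` gives 790 nM in this assay.

Compound 2 holds the lowest of the two numbers, but its nearest neighbour, compound 1, sits within the scatter of it, so the two read as equivalent on this evidence. Compound 3 `COc1cc2c(Oc3ccc(NC(=O)N/N=C/c4ccc(N(C)C)cc4)cc3F)ccnc2cc1OCCCN1CCCCC1` has not yet been measured. It differs from compound 2 in one place: 4-(dimethylamino)phenyl in place of 2-chloro-4-fluorophenyl on a carbon with a double bond to nitrogen. Both of the measured compounds carry the shared core unchanged and differ only in the aryl group on the carbon with a double bond to nitrogen, and their two values give no sign that this part of the molecule shifts the number beyond the scatter. Going by the values given here, with no measured step between a close pair to lean on, the expected change in this assay from compound 2 to compound 3 is none beyond the scatter, in either direction, and the step of a 1.3-fold higher number from compound 2 to compound 3 (0.10 log units; within the scatter) is the estimate. Compound 3 is therefore expected to give about 1000 nM in this assay, with a plausible range from 350 nM to 3000 nM.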

Compound 3, half-maximal inhibitory concentration: 1400 nM
Compound 3: the middle estimate sits 1.4-fold (0.15 log units) below what was measured; the measured number falls inside the stated range.
By their numbers in this assay, from the lowest: compounds 2, 1 and 3 (each within the scatter of the next).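

In this assay, the change from 2-chloro-4-fluorophenyl to 4-(dimethylamino)phenyl on a carbon with a double bond to nitrogen can now be read directly as a 1.8-fold higher number from compound 2 to compound 3 (0.25 log units; within the scatter). Compounds 1 and 2 differ in more than one place, so they could not isolate a change at this position. This single step shows that exchanging the two halogen-bearing ring for a ring carrying dimethylamino, with one hydrogen-bond acceptor entering where the leaving group had none, leaves the number within the scatter, and nothing measured here explains that outcome.

This one exchange does not show whether any group at this position can shift the number beyond the scatter, and a carboxylic acid or a primary amine on the phenyl ring in place of the dimethylamino group would test that. No single step shown reaches any other part of the molecule, so a longer chain elsewhere remains an open question too.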